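The compounds below may be only part of what the source reports. "The series", "measured", "known", "first", "only" and "open" are said of these compounds alone.

Three measured compounds share one core and were tested in a functional assay on HT-29 cells (Homo sapiens) for antiproliferative activity, read by sulforhodamine B assay, with a stated time of 48 h; a higher number here means a weaker inhibitor, a lower number a stronger inhibitor. Compound 1 `CC(C)c1ccccc1OS(=O)(=O)c1cccc(NC(=O)CCCl)c1` gives 11000 nM. Compound 2 `CCC(=O)Nc1ccc(S(=O)(=O)Oc2ccccc2C(C)C)cc1` gives 7400 nM, and compound 3 `CCC(=O)Nc1ccc(S(=O)(=O)Oc2ccccc2I)cc1` gives 11000 nM. Going by the values given here, the only step between two compounds that differ in a single place, a 1.5-fold higher number from compound 2 to compound 3 (0.17 log units; within the scatter), lies within the scatter. Compound 3 thus stands level with compound 1 at the digits shown, the two together at the high end of the three numbers, while compound 2 is the furthest from it and still within the scatter. Compound 1 and compound 2 differ in more than one place, so their two numbers can only be taken as they stand.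

Compound 4 `CCCCCC(=O)Nc1ccc(S(=O)(=O)Oc2ccccc2I)cc1` differs from compound 3 by propyl in place of hydrogen on a saturated chain carbon, two bonds along the chain from a carbonyl carbon. Among the compounds with values here, no measured step tests a change of this kind: the one step known concerns the other end of the molecule and changed little. Nothing in these data therefore points to a move in either direction for compound 4, and the expectation is a number close to that of compound 3, with a wide range to cover an untested change. Compound 4 is expected to show no change at the digits printed from compound 3 to compound 4 (within the scatter), giving an estimate of 11000 nM, between 3500 nM and 35000 nM.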

Compound 4, half-maximal inhibitory concentration: 13000 nM
For compound 4 the middle estimate is 1.2-fold (0.07 log units) below the measured one; the measured number falls inside the stated range.
By their numbers in this assay, from the lowest: compounds 2, 1, 3 and 4 (each within the scatter of the next).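

In this assay, the step of a 1.2-fold higher number from compound 3 to compound 4 (0.07 log units; within the scatter) lies within the scatter, so propyl in place of hydrogen on a saturated chain carbon, two bonds along the chain from a carbonyl carbon, leaves the number without a readable change. Going by these compounds alone, this is the only measured step on the chain, and it shows that going from propanoyl to pentylcarbonyl on the core of compound 3 is tolerated in this assay, something the earlier step at the other group, a 1.5-fold higher number from compound 2 to compound 3 (0.17 log units; within the scatter), could not show. No supporting evidence bears on this result, so the data offer no account of why the number holds.

What the compounds shown leave open is whether a group of another kind on this chain carbon, such as an amine, a carboxylic acid or a phenyl ring, or a chain longer than pentylcarbonyl, would move the number beyond the scatter. On these data alone, it also remains open whether the same propyl change would give a similar step on compound 2, which carries isopropyl in place of iodo.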